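Urea Pyrimidines Against a Lung Cancer Cell Line

The compounds below may be only part of what the source reports. "The series", "measured", "known", "first", "only" and "open" are said of these compounds alone.

Measured so far:
compound 1 `COc1cc(NC(=O)Nc2cc(Nc3ccc(C(C)(C)C)cc3)ncn2)cc(OC)c1` gives 17.5%
compound 2 `Cc1ccc(Nc2cc(NC(=O)Nc3c(Cl)cccc3Cl)ncn2)cc1F` gives 33.5%
compound 3 `Cc1ccc(Nc2cc(NC(=O)Nc3c(Cl)cccc3Cl)ncn2)cc1C` gives 47.5%

The three compounds were tested in a functional assay on NCI-H520 cells (Homo sapiens) for inhibition, read by MTT assay, with a stated time of 48 h, tested at 10 uM; a higher number here means more inhibition at the concentration tested (going by the name of the read-out), a lower number less inhibition. Compound 3 stands highest of the three, with compound 2 nearest and compound 1 furthest. Going by the values given here, the only one-place step is the move a number 14 percentage points higher from compound 2 to compound 3 (beyond the scatter), a change of substituent on the aryl ring attached to the ring nitrogen.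

Compound 4 `COc1ccc(Br)cc1Nc1cc(NC(=O)Nc2c(Cl)cccc2Cl)ncn1` has not been measured. It differs from compound 3 in that (5-bromo-2-methoxyphenyl in place of 3,4-dimethylphenyl on a nitrogen on an aromatic ring). Among the compounds with values here, no measured pair shows this exact change; the step from compound 2 to compound 3 is the only one on the same ring and touches only a single substituent, so it gives at best weak guidance. Compound 1, which carries a different aryl group on that nitrogen, sits well below compound 3, which suggests that the aryl group matters, but without a single-change comparison the direction is uncertain.

The author therefore expects a small step, a number 7.5 percentage points lower from compound 3 to compound 4 (within the scatter), that may well lie within the scatter. For compound 4 the estimate in this assay is 40%, with a range from 20% to 60%.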

Compound 4, a percentage reported as inhibition, at one concentration (the size of the read-out at that concentration, not a potency): 45%
For compound 4 the middle estimate is 5 percentage points below the measured one; measured number inside the range.
By their numbers in this assay, from the lowest: compound 1; then compound 2; then compounds 4 and 3 (each within the scatter of the next).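

In this assay, putting 5-bromo-2-methoxyphenyl in place of 3,4-dimethylphenyl on the nitrogen gives a number 2.5 percentage points lower from compound 3 to compound 4 (within the scatter), so this position takes an aryl group with a different substitution pattern, including an oxygen and a bromine, and the two numbers cannot be told apart. The same exchange made against 3-fluoro-4-methylphenyl gives a number 11.5 percentage points higher from compound 2 to compound 4 (beyond the scatter), which leaves compound 2 as the one set apart among the three compounds sharing that urea side. No measurement here bears on why these steps come out as they do. The bromine and the methoxy enter together, so the compounds shown leave open what each contributes alone. They also leave open whether an amine or a carboxylic acid on this aryl ring would keep the number at this level.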